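Changing the amine side chain of an ethyl ester

The source may hold more compounds than are shown below. What is called first, only, known or untested is meant among the compounds shown, and "the series" means these compounds.

Values from a functional assay on MCF7 cells (Homo sapiens) for inhibition, read by MTT assay, with a stated time of 3 days (on this read-out higher numbers stand for weaker inhibition and lower numbers for stronger inhibition), are these
compound 1 `CC[C@H](C)[C@@H](NCC(=O)NNC(=O)COc1ccc(-c2nc3ccccc3s2)cc1OC)C(=O)O` gives 1790 nM
compound 2 `COc1cc(-c2nc3ccccc3s2)ccc1OCC(=O)NNC(=O)CN(C(C)=O)[C@@H](CS)C(=O)O` gives 1750 nM
compound 3 `CCOC(=O)[C@H](NCC(=O)NNC(=O)COc1ccc(-c2nc3ccccc3s2)cc1OC)[C@@H](C)CC` gives 2900 nM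

Compound 3 at 2900 nM lies within the scatter of both compound 1 and compound 2, so all three values form one tight group. Compound 4 `CCOC(=O)[C@H](CCSC)NCC(=O)NNC(=O)COc1ccc(-c2nc3ccccc3s2)cc1OC` keeps the ethyl ester and alters only the group on the amine nitrogen: 1-(ethoxycarbonyl)-3-(methylsulfanyl)propyl in place of 1-(ethoxycarbonyl)-2-methylbutyl on an amine nitrogen is the whole change. Among the compounds with values here, two measured steps touch that same part of the molecule, namely a 1.0-fold lower number from compound 1 to compound 2 (0.01 log units; within the scatter) and a 1.7-fold higher number from compound 2 to compound 3 (0.22 log units; within the scatter) and neither exceeded the scatter. No step beyond the scatter is therefore expected in this assay for this smaller swap. The estimated step is a 1.2-fold lower number from compound 3 to compound 4 (0.06 log units; within the scatter) and it carries no clear direction. Compound 4 is expected at 2500 nM with an estimated range from 1200 nM to 5000 nM as its span.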

Compound 4, half-maximal inhibitory concentration: 1760 nM
Compound 4: middle estimate off by 1.4-fold (0.15 log units), on the high side; the range from low to high includes it.
By their numbers in this assay, from the lowest: compounds 2, 4, 1 and 3 (each within the scatter of the next).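

Replacing 1-(ethoxycarbonyl)-2-methylbutyl with 1-(ethoxycarbonyl)-3-(methylsulfanyl)propyl on the amine nitrogen keeps the ester and brings a sulfur into the side chain, yet in this assay the step stays small (a 1.6-fold lower number from compound 3 to compound 4 (0.22 log units; within the scatter)). Compound 4 also sits with both carboxylic acid compounds (a 1.0-fold higher number from compound 2 to compound 4 (0.00 log units; within the scatter); a 1.0-fold lower number from compound 1 to compound 4 (0.01 log units; within the scatter)), so all four values remain one group. Nothing measured here explains this closeness.

On these data alone, whether a side chain ending in a primary amine, or a benzyl group, on this nitrogen would move the number beyond the scatter remains open.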